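The source may hold more compounds than are shown below. What is called first, only, known or untested is meant among the compounds shown, and "the series" means these compounds.

In a functional assay on MGC-803 cells (Homo sapiens) for inhibition, read by CCK-8 assay, with a stated time of 48 h (a higher number here means a weaker inhibitor, a lower number a stronger inhibitor), compound 1 `COc1ccc(CN(C(=O)CSC(=S)N2CCCC2)c2cc(OC)c(OC)c(OC)c2)cc1` gives only a limit, > 20000 nM. Compound 2 `COc1ccc(CN(C(=O)CSC(=S)N2CCc3ccccc32)c2cc(OC)c(OC)c(OC)c2)cc1` gives 8410 nM. Compound 3 `COc1ccc(CN(C(=O)CSC(=S)N2CCc3cc(Br)ccc32)c2cc(OC)c(OC)c(OC)c2)cc1` is also only a limit, > 20000 nM, and so stands at the limit of > 20000 nM in this assay, at which 2 of the 3 values shown sit. Compound 4 `COc1ccc(CN(C(=O)CSC(=S)N2CCCc3cc(OC)ccc32)c2cc(OC)c(OC)c(OC)c2)cc1` differs from it on a thiocarbonyl carbon: 6-methoxy-1,2,3,4-tetrahydroquinolin-1-yl in place of 5-bromo-2,3-dihydro-1H-indol-1-yl on a thiocarbonyl carbon. Two measured steps at this place bear on the change, both at least modest and opposite in direction: an at least 2.3-fold lower number from compound 1 to compound 2 (0.37 log units; beyond the scatter), and an at least 2.3-fold higher number from compound 2 to compound 3 (0.37 log units; beyond the scatter) for bromo in place of hydrogen on an aromatic carbon. Among the compounds with values here, the new group carries no bromo, and no measured step covers the methoxy or the six-membered ring. A modest move to a lower number is expected, with an estimated at least 3.3-fold lower number from compound 3 to compound 4 (0.52 log units; beyond the scatter). Compound 4 is estimated at 6000 nM, within a range of 800 nM to 20000 nM.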

Compound 4, half-maximal inhibitory concentration: 8210 nM
Compound 4: middle estimate off by 1.4-fold (0.14 log units), on the low side; low and high end bracket the measured number.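

On the thiocarbonyl carbon, 6-methoxy-1,2,3,4-tetrahydroquinolin-1-yl gives a measurable value where the bromo analogue did not, an at least 2.4-fold lower number from compound 3 to compound 4 (0.38 log units; beyond the scatter), and also stands apart from pyrrolidin-1-yl, an at least 2.4-fold lower number from compound 1 to compound 4 (0.38 log units; beyond the scatter). Against unsubstituted 2,3-dihydro-1H-indol-1-yl it brings no gain, a 1.0-fold lower number from compound 2 to compound 4 (0.01 log units; within the scatter), so a six-membered non-aromatic ring carrying methoxy is accepted here, unlike bromo on the five-membered one. Compound 1 and compound 3 remain limits, not numbers: the limit of > 20000 nM in this assay, at which 2 of the 4 values shown sit.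

Going by these compounds, the methoxy and the six-membered ring change together, so their separate contributions remain open. Also open, on these data alone, is how unsubstituted 1,2,3,4-tetrahydroquinolin-1-yl, or an amine in place of the methoxy, would read.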